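Notes on the benzyloxy terminus: compounds 1 to 3

This account rests on a few compounds, and the source may have more. Where it says the series, first, only, none or still open, it means among the compounds named here.

Measured compounds:
compound 1 `FC(F)(F)c1ccc(CN2CCN(Cc3cc(-c4ccc(OCc5ccc(Cl)cc5)cc4)on3)CC2)cc1`: 6700 nM
compound 2 `Fc1ccc(COc2ccc(-c3cc(CN4CCN(Cc5ccc(C(F)(F)F)cc5)CC4)no3)cc2)cc1`: 7900 nM

In a functional assay on MCF7 cells (Homo sapiens) for antiproliferative activity, read by sulforhodamine B assay, with a stated time of 72 h (a lower number here means a stronger inhibitor, a higher number a weaker inhibitor), compound 1 gives 6700 nM. In this assay compound 2 gives 7900 nM. Compound 2 carries the higher of the two numbers, but the step of a 1.2-fold higher number from compound 1 to compound 2 (0.07 log units; within the scatter) lies within the scatter, so the two compounds cannot be ordered on these data.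

Compound 3 `COc1cccc(COc2ccc(-c3cc(CN4CCN(Cc5ccc(C(F)(F)F)cc5)CC4)no3)cc2)c1` is not yet measured. It differs from compound 2 by 3-methoxyphenyl in place of 4-fluorophenyl on a saturated chain carbon bound to an oxygen on an aromatic ring. Among the measured compounds shown here, the only measured step, a 1.2-fold higher number from compound 1 to compound 2 (0.07 log units; within the scatter), exchanged one halogen for another within the benzyloxy group and left the number essentially unchanged; it bears on the new step only in showing that a small change in that group passed without effect. For the measured compounds named here, no measured pair exchanges a halogen for a methoxy group, so the expectation rests on that single comparison alone.

The step from compound 2 to compound 3 is expected to be a 1.1-fold higher number from compound 2 to compound 3 (0.03 log units; within the scatter), that is none beyond the scatter. Compound 3 is therefore estimated at 8500 nM in this assay. The expected range for compound 3 runs from 3000 nM to 24000 nM.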

Compound 3, half-maximal inhibitory concentration: 2000 nM
For compound 3 the middle estimate is 4.3-fold (0.63 log units) above the measured one; the measured number lies below the stated range.
By their numbers in this assay, from the lowest: compound 3; then compounds 1 and 2 (each within the scatter of the next).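

In this assay the group on the saturated chain carbon bound to an oxygen on an aromatic ring is not a place where every exchange passes without effect: 3-methoxyphenyl in place of 4-fluorophenyl gives a 4.0-fold lower number from compound 2 to compound 3 (0.60 log units; beyond the scatter) and 3-methoxyphenyl in place of 4-chlorophenyl gives a 3.4-fold lower number from compound 1 to compound 3 (0.53 log units; beyond the scatter) in the same direction. The exchange of one halogen for the other, a 1.2-fold higher number from compound 1 to compound 2 (0.07 log units; within the scatter), did not register, so on these three compounds the terminus separates 3-methoxyphenyl from both halogenated groups but does not separate those two from each other. What lies behind the difference cannot be said, as no measurement at hand speaks to it.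

3-Methoxyphenyl differs from 4-fluorophenyl and 4-chlorophenyl both in the substituent and in where it sits, so the compounds shown leave open which of the two carries the step, and a 4-methoxyphenyl or a 3-fluorophenyl group would pull them apart. Also open, on these data alone, is whether the lower number persists with a 3-ethoxyphenyl or a 3-aminophenyl group at the same place.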